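Ring Opened to a tert-Butylamino Chain at the Ether

The source may hold more compounds than are shown below. What is called first, only, known or untested is meant among the compounds shown, and "the series" means these compounds.

In a functional assay on SK-BR-3 cells (Homo sapiens) for antiproliferative activity (on this read-out higher numbers stand for weaker inhibition and lower numbers for stronger inhibition), compound 2 `CC(C)=CCc1cc(C(=O)Nc2cc3ccc(OCC4CCCN(C)C4)c(C)c3oc2=O)ccc1O` gives 1300 nM, the highest of the three numbers measured. Compound 1 `CC(C)=CCc1cc(C(=O)Nc2cc3ccc(OCCC4CCCCN4)c(C)c3oc2=O)ccc1O` gives 640 nM, and compound 3 `CC(C)=CCc1cc(C(=O)Nc2cc3ccc(OCC4CCCNC4)c(C)c3oc2=O)ccc1O` gives 600 nM. The step of a 2.0-fold higher number from compound 1 to compound 2 (0.31 log units; beyond the scatter) and the step of a 2.2-fold lower number from compound 2 to compound 3 (0.34 log units; beyond the scatter) both place compound 2 at the weak end; the step of a 1.1-fold lower number from compound 1 to compound 3 (0.03 log units; within the scatter) shows compound 1 and compound 3 close together.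

Compound 4 `CC(C)=CCc1cc(C(=O)Nc2cc3ccc(OCCCNC(C)(C)C)c(C)c3oc2=O)ccc1O` is unmeasured. It differs from compound 2 as follows: 2-((tert-butyl)amino)ethyl in place of 1-methylpiperidin-3-yl on a saturated chain carbon bound to an oxygen on an aromatic ring. Going by the values given here, the change most like it is the one from compound 2 to compound 3, where the methyl on the amine nitrogen in a ring is replaced by hydrogen, which gave a modest lower number, a 2.2-fold lower number from compound 2 to compound 3 (0.34 log units; beyond the scatter). Among the compounds with values here, compound 4 likewise carries a hydrogen-bond donor on its nitrogen, so a modest lower number is expected in this assay, though no measured step shows a ring opened to a chain. Compound 4 is estimated at 700 nM, a range of 350 nM to 1400 nM, which means an expected step of a 1.9-fold lower number from compound 2 to compound 4 (0.27 log units; within the scatter).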

Compound 4, half-maximal inhibitory concentration: 660 nM
Estimate against measurement, compound 4: 1.1-fold (0.03 log units) above, within the range that was stated.
By their numbers in this assay, from the lowest: compounds 3, 1, 4 and 2 (each within the scatter of the next, the first and the last beyond it).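

In this assay, an open chain with no ring takes the place of the ring on a saturated chain carbon bound to an oxygen on an aromatic ring, and a 2.0-fold lower number from compound 2 to compound 4 (0.29 log units; within the scatter) stays short of what the scatter allows, unlike the step that only removed the methyl from the ring nitrogen. Against the two ring compounds with a hydrogen on nitrogen, the chain gives a 1.1-fold higher number from compound 3 to compound 4 (0.04 log units; within the scatter) and a 1.0-fold higher number from compound 1 to compound 4 (0.01 log units; within the scatter) as well, so among these compounds a ring at this place is not required to reach their numbers. Compound 4 thus sits within the scatter of all three ring compounds, although compounds 1 and 3 lie beyond it from compound 2. The compounds shown leave open how an isopropyl or a methyl in place of the tert-butyl on the chain nitrogen would compare, and how a dimethylamino end or a longer chain would read. No measured evidence is available to explain this result.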